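Replacing cyclopentyl with cyclohexylamino on the shared core

This account rests on a few compounds, and the source may have more. Where it says the series, first, only, none or still open, it means among the compounds named here.

The study compares three compounds on a shared core, measured in a functional assay on HCT-116 cells (Homo sapiens) for cytotoxicity, with a stated time of 48 h; a higher number here means a weaker inhibitor of growth, a lower number a stronger inhibitor of growth. Compound 1 `CCc1cc(-c2cc(N3C[C@H](O)[C@@H](O)C3)ccc2O)nc(N)n1` carries an ethyl group on an aromatic carbon; in this assay compound 1 gives 1000 nM. Compound 2 `Nc1nc(-c2cc(N3C[C@H](O)[C@@H](O)C3)ccc2O)cc(C2CCCC2)n1` carries cyclopentyl in the same place, and in this assay compound 2 gives 400 nM. Among the measured compounds shown here, the single measured step, a 2.5-fold lower number from compound 1 to compound 2 (0.40 log units; beyond the scatter), is modest but beyond the scatter, so compound 2 stands with the lowest of the two numbers, with compound 1 as its nearest and only neighbour.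

Compound 3 `Nc1nc(NC2CCCCC2)cc(-c2cc(N3C[C@H](O)[C@@H](O)C3)ccc2O)n1` has not yet been measured. It differs from compound 2 in one place: cyclohexylamino in place of cyclopentyl on an aromatic carbon

For the measured compounds named here, only the step from compound 1 to compound 2 bears on this change, and it concerns a different pair of groups on the same aromatic carbon. It shows that a larger non-aromatic ring in this place was tolerated and gave the lower number, but nothing measured speaks to the cyclohexylamino group itself. The expectation for compound 3 is therefore cautious: a step of roughly a 1.1-fold lower number from compound 2 to compound 3 (0.06 log units; within the scatter), which may well fall within the scatter. Compound 3 is estimated at 350 nM, with a range from 100 nM to 1200 nM.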

Compound 3, concentration for 50% growth inhibition: 900 nM
Beside the measured number, compound 3's estimate is 2.6-fold (0.41 log units) below it, within the range that was stated.
By their numbers in this assay, from the lowest: compound 2; then compounds 3 and 1 (each within the scatter of the next).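

In this assay, among the compounds shown here, the earlier compounds left room to read a larger group on this aromatic carbon as giving a lower number, but cyclohexylamino does not follow that reading, with a 2.3-fold higher number from compound 2 to compound 3 (0.35 log units; beyond the scatter). Set against the small ethyl group, the same change gives a 1.1-fold lower number from compound 1 to compound 3 (0.05 log units; within the scatter), so among these three compounds the lower number belongs to cyclopentyl alone and does not simply track group size. Nothing available explains why cyclopentyl and cyclohexylamino differ at this position.

The change from compound 2 to compound 3 alters two things at once, the ring size and the nitrogen that joins the ring to the aromatic carbon, and the compounds shown cannot separate them. Cyclohexyl attached directly to the aromatic carbon, or cyclopentylamino, would tell whether the higher number goes with the six-membered ring or with the amine link, while an open-chain amine such as butylamino would test whether the ring is needed at all.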